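Replacing the Phenol on the Imine Aryl Ring

The source may hold more compounds than are shown below. What is called first, only, known or untested is meant among the compounds shown, and "the series" means these compounds.

Measured so far in a functional assay on the whole organism with Rattus norvegicus as the target; a lower number here means that less compound is needed, a higher number that more compound is needed for the effect:
compound 1 `CC1CCC(/C=N/c2ccccc2C(=O)O)=C2NC=C(C(=O)O)C(=O)N21`: 1.11 umol/kg
compound 2 `CC1CCC(/C=N/c2ccccc2O)=C2NC=C(C(=O)O)C(=O)N21`: 4.11 umol/kg

Compound 2 stands highest of the two numbers, set apart from compound 1 by a 3.7-fold higher number from compound 1 to compound 2 (0.57 log units; beyond the scatter). Compound 3 `Cc1ccc(/N=C/C2=C3NC=C(C(=O)O)C(=O)N3C(C)CC2)cc1` differs from compound 2 by 4-methylphenyl in place of 2-hydroxyphenyl on a double-bonded nitrogen. For the measured compounds named here, only one measured step bears on this change: a 3.7-fold higher number from compound 1 to compound 2 (0.57 log units; beyond the scatter), a modest shift from swapping one group on the same aromatic ring. A further rise in this assay, of similar size, is therefore expected, a 2.2-fold higher number from compound 2 to compound 3 (0.34 log units; beyond the scatter). Compound 3 is estimated at 9 umol/kg, within 3 umol/kg to 30 umol/kg.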

Compound 3, dose for 50% inhibition: 3.6 umol/kg
Compound 3: middle estimate off by 2.5-fold (0.40 log units), on the high side; measured number inside the range.
By their numbers in this assay, from the lowest: compound 1; then compounds 3 and 2 (each within the scatter of the next).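

In this assay, the swap at this place leaves the number within the scatter (a 1.1-fold lower number from compound 2 to compound 3 (0.06 log units; within the scatter)), so the hydroxy group of 2-hydroxyphenyl is not needed to hold it there. This holds even though 4-methylphenyl has no hydrogen-bond donor or acceptor. No measurement on hand accounts for the two aryl groups reading alike.

The change alters both the group and where it sits on the ring, and the compounds shown cannot separate the two. As far as these compounds go, whether an amine or a methoxy group on this ring would hold the number or approach compound 1 (1.11 umol/kg) remains open.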